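A Chloro for a Methyl in a HeLa Cytotoxicity Series

The source may hold more compounds than are shown below. What is called first, only, known or untested is meant among the compounds shown, and "the series" means these compounds.

In a functional assay on HeLa cells (Homo sapiens) for cytotoxicity, read by ELISA, with a stated time of 4 days (a lower number here means a stronger inhibitor, a higher number a weaker inhibitor), compound 1 (`Cc1ccsc1-c1cc(-c2ccco2)cc(-c2ccccc2Cl)n1`) gives 24000 nM and compound 2 (`Cc1ccsc1-c1cc(-c2ccoc2)cc(-c2ccc(Cl)cc2)n1`) gives 17400 nM while compound 3 (`Cc1ccccc1-c1cc(-c2ccoc2)cc(-c2ccc(Cl)s2)n1`) gives 19000 nM on the same scale. Compound 3 thus stands level with the other two, since all three numbers lie within the usual scatter of one another. Compound 4 (`Clc1ccc(-c2cc(-c3ccoc3)cc(-c3ccccc3Cl)n2)s1`) puts chloro in place of methyl on an aromatic carbon, ortho to a large group, turning 2-methylphenyl into 2-chlorophenyl (chloro in place of methyl on an aromatic carbon). Within the data shown here, no measured pair shows this change alone, but compound 1 also carries 2-chlorophenyl and gives 24000 nM in the same range. The step expected in this assay is a 1.1-fold higher number from compound 3 to compound 4 (0.02 log units; within the scatter) and so stays within the scatter. For compound 4 the estimated value is 20000 nM with an expected range from 10000 nM to 40000 nM in this test.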

Compound 4, half-maximal inhibitory concentration: 19000 nM
Beside the measured number, compound 4's estimate is 1.1-fold (0.02 log units) above it; the measured number falls inside the stated range.
By their numbers in this assay, from the lowest: compounds 2, 3, 4 and 1 (each within the scatter of the next).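

In this assay, among these compounds, the change from 2-methylphenyl to 2-chlorophenyl can now be read on its own, as no change at the digits printed from compound 3 to compound 4 (within the scatter) and this is the first single-place step. In this one pair, chloro in place of methyl, ortho to a large group, leaves the cytotoxicity reading where it was. No measurement here offers a reason for this.

From the compounds shown here alone, whether an amine, a carboxylic acid or a longer chain at this position would shift the number remains open. So does whether the same swap behaves alike on other versions of the shared core.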